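Acyl exchange on compound 3: expected outcome

The compounds below may be only part of what the source reports. "The series", "measured", "known", "first", "only" and "open" are said of these compounds alone.

Three compounds of the series have numbers in a functional assay on MDA-MB-231 cells (Homo sapiens) for antiproliferative activity, read by MTT assay, with a stated time of 72 h; a higher number here means a weaker inhibitor, a lower number a stronger inhibitor. Compound 1 `CC1=CC[C@H]2[C@@H]1CC=C(C)[C@@H](CC[C@H]1[C@]3(C)CC[C@H](OC(=O)CCC(=O)O)C(C)(C)O[C@H]3CC[C@@]1(C)O)C2(C)C` gives 29600 nM, compound 2 `CC1=CC[C@H]2[C@@H]1CC=C(C)[C@@H](CC[C@H]1[C@]3(C)CC[C@H](OCc4ccccc4)C(C)(C)O[C@H]3CC[C@@]1(C)O)C2(C)C` gives 35700 nM, and compound 3 `CC1=CC[C@H]2[C@H](CC[C@]2(C)O)C(C)(C)[C@@H]1CC[C@H]1[C@]2(C)CC[C@H](OC(=O)c3ccc(F)cc3)C(C)(C)O[C@H]2CC[C@@]1(C)O` gives 11300 nM. Compound 3 stands lowest of the three, with compound 1 nearest and beyond the scatter above it, and compound 2 furthest. Among the compounds with values here, the single measured step, a 1.2-fold higher number from compound 1 to compound 2 (0.08 log units; within the scatter), changes a group on an oxygen on a saturated carbon and stays within the scatter.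

Compound 4 `CC1=CC[C@H]2[C@H](CC[C@]2(C)O)C(C)(C)[C@@H]1CC[C@H]1[C@]2(C)CC[C@H](OC(=O)c3ccc([N+](=O)[O-])o3)C(C)(C)O[C@H]2CC[C@@]1(C)O` is not yet measured. It differs from compound 3 by 5-nitrofuran-2-yl in place of 4-fluorophenyl on a carbonyl carbon. Within the data shown here, no measured step changes the group on a carbonyl carbon; the step from compound 1 to compound 2 is the only change at the same oxygen and, being within the scatter, bears only loosely. With nothing pointing in either direction, no step beyond the scatter is expected, and the estimated step is no change at the digits printed from compound 3 to compound 4 (within the scatter). Compound 4 is therefore expected to give about 11300 nM in this assay, within a range of 4000 nM to 32000 nM.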

Compound 4, half-maximal inhibitory concentration: 11100 nM
Compound 4: the middle estimate sits 1.0-fold (0.01 log units) above what was measured; low and high end bracket the measured number.
By their numbers in this assay, from the lowest: compounds 4 and 3 (each within the scatter of the next); then compounds 1 and 2 (each within the scatter of the next).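

In this assay, within the data shown here, 5-nitrofuran-2-yl in place of 4-fluorophenyl on the carbonyl carbon gives a 1.0-fold lower number from compound 3 to compound 4 (0.01 log units; within the scatter) and is the first measured step at this carbonyl carbon. The two groups differ in ring size, hetero atoms and hydrogen-bond acceptor count, yet the values of the pair lie within the scatter of each other, so this position holds both aromatic acyl groups at one level in this assay. No measurement shown here explains this result.

On these data alone, whether an amine or a long alkyl chain on the carbonyl carbon would also stay within the scatter of compound 3 remains open. Also open, as far as these compounds go, is whether these two acyl groups would read alike on the core of compound 1, since the pair shares only the core of compound 3.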